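The compounds below may be only part of what the source reports. "The series", "measured", "known", "first", "only" and "open" are said of these compounds alone.

In an ADME assay on CHO cells (Cricetulus griseus) for cytotoxicity, read by MTT assay, with a stated time of 24 h (a lower number here means that less compound is tolerated, a higher number that more compound is tolerated), compound 1 `CC1Cn2c(nc([N+](=O)[O-])c2-c2ccc(CO)cc2)O1` gives > 500000 nM, which is a limit and not a number. Compound 2 `CC1Cn2c(nc([N+](=O)[O-])c2-c2ccc(Cl)cc2)O1` gives > 250000 nM, also a limit. Compound 3 `Cc1ccc(-c2c([N+](=O)[O-])nc3n2CC(C)O3)s1` gives > 125000 nM, again a limit. Compound 4 `CC1Cn2c(nc([N+](=O)[O-])c2-c2ccc(C=O)cc2)O1` alters compound 1 in one place, formyl in place of hydroxymethyl on an aromatic carbon, para to a large group. Among the compounds with values here, the one measured step that replaces this same hydroxymethyl is a step that the two limits leave unreadable from compound 1 to compound 2, so it offers no size to carry over. Within the data shown here, with only that step as a guide, no change beyond the usual scatter is expected in this assay. The estimated move is an at least 1.4-fold lower number from compound 1 to compound 4 (0.15 log units; that floor lies within the scatter). For compound 4 the expected value is 350000 nM, with an estimated range of 120000 nM to 500000 nM.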

Compound 4, half-maximal cytotoxic concentration: 255000 nM
For compound 4 the middle estimate is 1.4-fold (0.14 log units) above the measured one; the measured number falls inside the stated range.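

In this assay, within the data shown here, compound 4 is the first compound here to give a real number rather than a limit, 255000 nM. Replacing hydroxymethyl with formyl on this aromatic carbon gives an at least 1.9-fold lower number from compound 1 to compound 4 (0.29 log units; that floor lies within the scatter), so the change may or may not exceed the usual scatter. That size is only a floor because compound 1 is held at a limit, and the step from compound 2 to compound 4 cannot be read either: the limit of > 500000 nM in this assay, at which 1 of the 4 values shown sits.

As far as these compounds go, the true number for compound 1 remains open. So does what an amine or a carboxylic acid on this same carbon would give.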